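The compounds below may be only part of what the source reports. "The series", "measured", "known", "first", "only" and "open" are said of these compounds alone.

Measured so far:
- compound 1, `COc1ccc(Cl)cc1-c1cc(Nc2ccc(Cl)cc2)nc(N)n1`: 54 nM
- compound 2, `CCOc1ccc(Br)cc1-c1cc(Nc2ccc(C(C)=O)cc2)nc(N)n1`: 34 nM
- compound 3, `CCOc1ccc(Cl)cc1-c1cc(Nc2ccccc2Cl)nc(N)n1`: 4900 nM

In an assay on Sf9 cells for inhibition of 1-acyl-sn-glycerol-3-phosphate acyltransferase beta (Homo sapiens) (a lower number here means a stronger inhibitor, a higher number a weaker inhibitor), compound 3 gives the highest of the three numbers. The nearest of the others is compound 1, whose value in this assay is lower by a margin well beyond the scatter, and compound 2 lies further still. Compound 3 is thus the weakest of the three measured inhibitors, and it is the only one that carries a 2-chlorophenyl on the nitrogen attached to the shared core.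

Compound 4, `CCOc1ccc(Cl)cc1-c1cc(Nc2ccc([N+](=O)[O-])cc2)nc(N)n1`, has not yet been measured. It differs from compound 3 in one place: 4-nitrophenyl in place of 2-chlorophenyl on a nitrogen on an aromatic ring. Going by the values given here, no step between two measured compounds matches this change, so the size of the step is open. Since compound 1 gives 54 nM and compound 2 gives 34 nM in this assay, both far below compound 3, the step from compound 3 to compound 4 is expected to be large and downward, a 110-fold lower number from compound 3 to compound 4 (2.04 log units; beyond the scatter). Compound 4 is estimated at 45 nM in this assay, within a range from 10 nM to 300 nM.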

Compound 4, half-maximal inhibitory concentration: 10 nM
For compound 4 the middle estimate is 4.5-fold (0.65 log units) above the measured one; the range from low to high includes it.
By their numbers in this assay, from the lowest: compound 4; then compounds 2 and 1 (each within the scatter of the next); then compound 3.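

In this assay, going by these compounds alone, exchanging 2-chlorophenyl for 4-nitrophenyl on the nitrogen, with the rest of the molecule held fixed, gives a 490-fold lower number from compound 3 to compound 4 (2.69 log units; beyond the scatter) and so shows that this one position can move the number strongly, which the earlier compounds, differing in several places at once, could not show. The exchange alters the substituent and its place on the phenyl ring in a single move, so the step cannot be divided between the two. Nothing measured here bears on why this exchange has so large an effect.

The compounds shown leave open whether 2-nitrophenyl on this nitrogen would give a number near that of compound 3 or that of compound 4. They also leave open how unsubstituted phenyl, 4-aminophenyl or 4-carboxyphenyl would behave in the same place.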